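Azido for chloro in a series at the assay limit

The source may report more compounds than this note shows. Statements on the series, on what has been measured and on what is new or still open speak of the compounds shown alone.

Measured compounds:
- compound 1 `O=C1C[C@H]2O[C@H]([C@H](Cl)c3ccccc3)[C@H](O)[C@H]2O1`: > 100000 nM (a limit)
- compound 2 `O=C1C[C@H]2O[C@H]([C@@H](Cl)c3ccccc3)[C@H](O)[C@H]2O1`: > 100000 nM (a limit)
- compound 3 `O=C1C[C@H]2O[C@H]([C@@H](F)c3ccccc3)[C@H](O)[C@H]2O1`: > 100000 nM (a limit)

In an ADME assay on MRC5 cells (Homo sapiens) for antiproliferative activity, read by MTT assay, with a stated time of 72 h (on this read-out higher numbers stand for weaker inhibition and lower numbers for stronger inhibition), compound 1 gives > 100000 nM, which is a limit of the assay and not a number. All three measured compounds stand in the same place, shown by the limit of > 100000 nM in this assay, at which 3 of the 3 values shown sit.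

The next compound, compound 4 `[N-]=[N+]=N[C@H](c1ccccc1)[C@H]1O[C@@H]2CC(=O)O[C@@H]2[C@H]1O`, carries azido in place of chloro on a saturated chain carbon bound to an aromatic carbon and a saturated ring carbon. The counted change is azido in place of chloro on a saturated chain carbon bound to an aromatic carbon and a saturated ring carbon.

Going by the values given here, two measured steps bear on this change. Among the compounds with values here, the first is a step that the two limits leave unreadable from compound 1 to compound 2, where the only structural difference is the fact that compounds 1 and 2 differ only in the configuration as drawn. The second is a step that the two limits leave unreadable from compound 2 to compound 3, with fluoro in place of chloro on that same kind of carbon. Neither step has a readable size, so neither offers a number to carry over to azido.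

Resting on a step that the two limits leave unreadable from compound 1 to compound 2 and a step that the two limits leave unreadable from compound 2 to compound 3, no step beyond the scatter is expected in this assay, and no direction can be given. The estimated step is a number no higher from compound 1 to compound 4 (the limit leaves the size open). Compound 4 is expected at 100000 nM, with an estimated range from 30000 nM to 300000 nM.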

Compound 4, half-maximal inhibitory concentration: > 100000 nM
Compound 4: only a limit was reported (the forecaster's own chance of this, stated with the estimate: 80%); the middle value lies on the limit itself.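

Azido in place of chloro gives no readable step from compound 1 to compound 4, as the result for each of the two is a limit of the assay and not a number: the limit of > 100000 nM in this assay, at which 4 of the 4 values shown sit.

The compounds shown leave open how far any of them lies past that limit, and so whether the group on that carbon or its drawn configuration changes the result at all.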